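Bromobenzyl thiopyrimidinones: cytotoxicity notes on the series

The source may report more compounds than this note shows. Statements on the series, on what has been measured and on what is new or still open speak of the compounds shown alone.

Measured compounds:
- compound 1, `COc1ccc(CSc2nc(Cc3cccc(Br)c3)c(C)c(=O)[nH]2)cc1`, > 290000 nM
- compound 2, `CCc1c(Cc2ccccc2Br)nc(SCc2ccc(OC)cc2)[nH]c1=O`, 165000 nM
- compound 3, `CCc1c(Cc2ccccc2Br)nc(SCc2ccc([N+](=O)[O-])cc2)[nH]c1=O`, > 272000 nM

For the measured compounds named here, in an ADME assay on MT4 cells (Homo sapiens) for cytotoxicity, read by MTT assay (on this read-out higher numbers stand for lower toxicity in this test and lower numbers for higher toxicity in this test), compound 2 gives 165000 nM, the only full number in the set. For compound 1 the value is a limit of the assay, (the limit of > 290000 nM in this assay, at which 1 of the 3 values shown sits). For compound 3 the value is likewise a limit, (the limit of > 272000 nM in this assay, at which 1 of the 3 values shown sits). Going by the values given here, the one measured step, an at least 1.6-fold higher number from compound 2 to compound 3 (0.21 log units; that floor lies within the scatter), sits within the scatter.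

Compound 4, `CCc1c(Cc2cccc(Br)c2)nc(SCc2ccc(OC)cc2)[nH]c1=O`, is still unmeasured. It differs from compound 2 by 3-bromophenyl in place of 2-bromophenyl on a saturated chain carbon bound to an aromatic carbon. Among the compounds with values here, no measured step touches this exchange; the nearest neighbour is compound 1, which differs from compound 4 in its alkyl group and shows only a limit. Within the data shown here, the single measured step gives no sign of a large move, and the two limits sit at the high end. Compound 4 is therefore expected at about 220000 nM, within 110000 nM to 400000 nM, a step of a 1.3-fold higher number from compound 2 to compound 4 (0.12 log units; within the scatter) that is estimated to stay within the scatter.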

Compound 4, half-maximal cytotoxic concentration: 201000 nM
Compound 4: the middle estimate sits 1.1-fold (0.04 log units) above what was measured, within the range that was stated.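

For the compounds shown here, the exchange of 3-bromophenyl for 2-bromophenyl on a saturated chain carbon bound to an aromatic carbon gives the first readable step at this position in this assay, a 1.2-fold higher number from compound 2 to compound 4 (0.09 log units; within the scatter), so the two bromophenyl groups are not told apart here. The exchange of methyl for hydrogen at that kind of carbon gives an at least 1.4-fold lower number from compound 1 to compound 4 (0.15 log units; that floor lies within the scatter), so only a floor is known and it does not separate the two compounds. That floor rests on a limit of the assay for compound 1: the limit of > 290000 nM in this assay, at which 1 of the 4 values shown sits.

Still open, as far as these compounds go, is whether any group at this position moves the read-out beyond the scatter, for example an amine or a carboxylic acid on the phenyl ring in place of the bromine. Also open, from the compounds shown here alone, is whether a longer chain, such as propyl, in place of the alkyl group on the core does so.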